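The compounds below may be only part of what the source reports. "The series", "measured", "known", "first", "only" and "open" are said of these compounds alone.

Working notes on the series in a functional assay on MT4 cells (Homo sapiens) for cytotoxicity; a higher number here means that more compound is tolerated, a lower number that less compound is tolerated.

Compound 1 `COC(=O)C1N=C(S)N(Nc2cccc(Cl)c2)C1C` gives 48800 nM in this assay. Compound 2 `CC1N=C(S)N(Nc2cccc(Cl)c2)C1C` gives 259000 nM. Compound 3 `COC(=O)C1C(C)N=C(S)N1Nc1cccc(Cl)c1` gives 190000 nM. The step of a 5.3-fold higher number from compound 1 to compound 2 (0.72 log units; beyond the scatter) is the only one beyond the scatter; the step of a 1.4-fold lower number from compound 2 to compound 3 (0.13 log units; within the scatter) is not. Compound 2 therefore holds the highest number of the three, though compound 3 sits within the scatter of it and only compound 1 is clearly apart.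

Compound 4 `Cc1cccc(NN2C(S)=NC(C)C2C)c1` differs from compound 2 by methyl in place of chloro on an aromatic carbon. Going by the values given here, neither measured step touches the aromatic ring: both concern the substituent on a saturated ring carbon, so no measured step bears directly on this change. There is no basis in the three measured compounds for expecting a shift in this assay beyond the scatter, and the expectation is a step near zero, a 1.0-fold lower number from compound 2 to compound 4 (0.02 log units; within the scatter). On that basis compound 4 is estimated at 250000 nM in this assay, with a range from 100000 nM to 600000 nM.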

Compound 4, half-maximal cytotoxic concentration: 360000 nM
The estimate for compound 4 lay 1.4-fold (0.16 log units) below the measured number; the measured number falls inside the stated range.
By their numbers in this assay, from the lowest: compound 1; then compounds 3, 2 and 4 (each within the scatter of the next).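

In this assay, going by these compounds alone, the exchange of chloro for methyl on the aromatic carbon gives a 1.4-fold higher number from compound 2 to compound 4 (0.14 log units; within the scatter), the first measured change on the aromatic ring, and it stays within the scatter. Between these two groups at this place, the number does not separate, while the one step beyond the scatter remains a 5.3-fold higher number from compound 1 to compound 2 (0.72 log units; beyond the scatter) on a saturated ring carbon. Nothing available explains the size of the new step.

As far as these compounds go, whether an amine, a carboxylic acid or a methoxy group on this aromatic carbon would also leave the number within the scatter remains open. Also open, from the compounds shown here alone, is whether the exchange of chloro for methyl would behave the same way in a compound carrying methoxycarbonyl on the saturated ring carbon.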